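Variations on the ring nitrogen substituent of the shared core

This account rests on a few compounds, and the source may have more. Where it says the series, first, only, none or still open, it means among the compounds named here.

Measured compounds:
Compound 1 `Cc1nc(S(C)(=O)=O)ccc1Oc1ncnc(OC2CCN(C(=O)OC(C)(C)C(F)(F)F)CC2)c1F` gives 79% in a functional assay on isolated protein for inhibition of Glucose-dependent insulinotropic receptor (Rattus norvegicus), read by HTRF and cAMP accumulation; a higher number here means a larger maximal response, a lower number a smaller maximal response.
Compound 2 `Cc1nc(S(C)(=O)=O)ccc1Oc1ncnc(OC2CCN(C(=O)OC(C)F)CC2)c1F` gives 68% in this assay.
Compound 3 `Cc1nc(S(C)(=O)=O)ccc1Oc1ncnc(OC2CCN(C(=O)SC3CCC3)CC2)c1F` gives 81% in this assay.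

Compound 3 holds the highest of the three numbers. The nearest is compound 1, with a number 2 percentage points higher from compound 1 to compound 3 (within the scatter), so the two cannot be ordered. The furthest is compound 2, with a number 13 percentage points higher from compound 2 to compound 3 (beyond the scatter), a modest step. Compound 4 `Cc1nc(S(C)(=O)=O)ccc1Oc1ncnc(OC2CCN(C(=S)OC(C)C)CC2)c1F` differs from compound 3 in one place: a group of 6 heavy atoms (4 carbon, 1 oxygen, 1 sulfur; no ring) in place of a group of 7 heavy atoms (5 carbon, 1 oxygen, 1 sulfur; one four-membered non-aromatic ring of carbon only), on an amine nitrogen in a ring.

Going by the values given here, two measured steps bear on this region. Swapping the group on the carbonyl carbon gave a number 2 percentage points higher from compound 1 to compound 3 (within the scatter), while a number 11 percentage points lower from compound 1 to compound 2 (beyond the scatter) and a number 13 percentage points higher from compound 2 to compound 3 (beyond the scatter) were modest. Among the compounds with values here, no measured step changes the carbonyl oxygen itself to sulfur, so that part is untested. In this assay a modest downward step, a number 8 percentage points lower from compound 3 to compound 4 (within the scatter), is expected for compound 4. Compound 4 is estimated at 73%, with a range from 60% to 86%.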

Compound 4, largest response reached (reported as efficacy), in percent of the reference or control that the assay uses: 47%
Compound 4: middle estimate off by 26 percentage points, on the high side, and the stated range ends above it.
By their numbers in this assay, from the lowest: compound 4; then compound 2; then compounds 1 and 3 (each within the scatter of the next).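

In this assay, compound 4 falls below all three carbonyl compounds, with a number 34 percentage points lower from compound 3 to compound 4 (beyond the scatter) and a number 32 percentage points lower from compound 1 to compound 4 (beyond the scatter) as well as a number 21 percentage points lower from compound 2 to compound 4 (beyond the scatter) (all beyond the scatter). Sulfur alone does not track with the lower number, since compound 3 also holds sulfur, on the carbonyl carbon, and stays within the scatter of compound 1. No evidence on the reason for the drop is available.

The swap at the double bond and the change of the group on oxygen remain inseparable here. On these data alone, how an amine on the carbonyl carbon would compare is also open.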